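Working notes: trifluoromethyl in place of chloro on compound 2

The source may report more compounds than this note shows. Statements on the series, on what has been measured and on what is new or still open speak of the compounds shown alone.

Measured in a functional assay on HeLa cells (Homo sapiens) for antiproliferative activity, with a stated time of 24 h (a higher number here means a weaker inhibitor, a lower number a stronger inhibitor), so far
- compound 1 `NC(=O)c1c(NC(=O)c2ccccc2Cl)sc2c1CCN(C(=S)Nc1ccccc1C(F)(F)F)C2` gives 26700 nM
- compound 2 `COc1ccccc1NC(=S)N1CCc2c(sc(NC(=O)c3ccccc3Cl)c2C(N)=O)C1` gives > 50000 nM
- compound 3 `NC(=O)c1c(NC(=O)c2ccccc2Cl)sc2c1CCN(C(=S)Nc1ccccc1-c1ccccc1)C2` gives 24000 nM

In this assay compound 2 reads > 50000 nM as a limit and not a number. Compound 4 (`COc1ccccc1NC(=S)N1CCc2c(sc(NC(=O)c3ccccc3C(F)(F)F)c2C(N)=O)C1`) differs from it by trifluoromethyl in place of chloro on an aromatic carbon on an aromatic carbon of a six-membered aromatic ring of carbon only, ortho to a large group, and so carries 2-(trifluoromethyl)phenyl in place of 2-chlorophenyl. Within the data shown here, all three measured compounds hold 2-chlorophenyl, so no measured step touches this group. The measured steps all lie elsewhere on the molecule. Methoxy in place of trifluoromethyl gives an at least 1.8-fold higher number from compound 1 to compound 2 (0.27 log units; that floor lies within the scatter) and phenyl in place of trifluoromethyl gives a 1.1-fold lower number from compound 1 to compound 3 (0.05 log units; within the scatter) while phenyl in place of methoxy gives an at least 2.0-fold lower number from compound 2 to compound 3 (0.31 log units; beyond the scatter) at that same place. These steps give no direction for the new change, so no step beyond the scatter is expected in this assay for it. An estimated at least 1.1-fold lower number from compound 2 to compound 4 (0.04 log units; that floor lies within the scatter) is expected. For compound 4 the estimated value is 45000 nM with an expected range from 20000 nM to 90000 nM and a report as a limit remains likely.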

Compound 4, half-maximal inhibitory concentration: > 50000 nM
Compound 4: a limit, no number; the forecaster's own chance of this, stated with the estimate: 55%; middle value at least 1.1-fold (0.04 log units) from the limit.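

In this assay compound 4 gives > 50000 nM, a limit and not a number. Among these compounds, compound 2 gives > 50000 nM, also a limit, so no step from compound 2 to compound 4 can be read. The compounds shown leave open whether trifluoromethyl in place of chloro changes this read-out at all.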